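Acetoxy-coumarin thienyl series: bromothiophene variant, expected binding

The compounds below may be only part of what the source reports. "The series", "measured", "known", "first", "only" and "open" are said of these compounds alone.

Measured so far:
- compound 1 `CC(=O)Oc1cccc2cc(-c3cccs3)c(=O)oc12`: in an assay on CHO cells for displacement of a labelled ligand from adenosine receptor A1 (Homo sapiens) (a higher number here means a weaker inhibitor, a lower number a stronger inhibitor), compound 1 gives > 100000 nM, a limit of the assay.
- compound 2 `CC(=O)Oc1cccc2cc(-c3ccsc3)c(=O)oc12`: in this assay compound 2 gives > 100000 nM, a limit of the assay.
- compound 3 `CC(=O)Oc1ccc2cc(-c3ccsc3)c(=O)oc2c1OC(C)=O`: in this assay compound 3 gives > 100000 nM, a limit of the assay.

Among the compounds with values here, compound 2 stands only as a limit in this assay, and the two other values shown are limits as well; no compound of the set has a number. The two measured steps, thiophen-3-yl in place of thiophen-2-yl a step that the two limits leave unreadable from compound 1 to compound 2 and acetoxy in place of hydrogen a step that the two limits leave unreadable from compound 2 to compound 3, are both unreadable because of the limit of > 100000 nM in this assay, at which 3 of the 3 values shown sit.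

The untested compound 4 `CC(=O)Oc1cccc2cc(-c3cc(Br)cs3)c(=O)oc12` differs from compound 2 as follows: 4-bromothiophen-2-yl in place of thiophen-3-yl on an aromatic carbon. Within the data shown here, neither measured step bears readably on this change, since both sit at the limit; the only guidance is that every variation of the thienyl group and of the acetoxy pattern so far has stayed unreadable in this assay. No step beyond the scatter is therefore expected, and the result is most likely again a limit. Compound 4 is estimated at 100000 nM in this assay, within 30000 nM to 300000 nM, a step of a number no higher from compound 2 to compound 4 (the limit leaves the size open) that is expected to be essentially none.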

Compound 4, inhibition constant: > 100000 nM
Compound 4: a limit, no number; the forecaster's own chance of this, stated with the estimate: 85%; the middle value lies on the limit itself.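

The steps to compound 4 from compound 2 and from compound 1 cannot be read in this assay because all these compounds stand at one limit: the limit of > 100000 nM in this assay, at which 4 of the 4 values shown sit.

The compounds shown leave open what size of effect, if any, the thienyl, bromo and acetoxy variations on the shared core have in this assay as a number.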